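This account rests on a few compounds, and the source may have more. Where it says the series, first, only, none or still open, it means among the compounds named here.

The core of compound 1 `N#Cc1ccc(F)cc1Cn1c(N2CCC[C@@H](N)C2)nc2c(-c3cccs3)c[nH]c2c1=O` carries thiophen-2-yl on an aromatic carbon, and in an ADME assay on microsomes from liver (Rattus norvegicus) for metabolic stability, read by LC-MS, tested at 1 mM (on this read-out higher numbers stand for a longer-lived compound and lower numbers for a shorter-lived compound), compound 1 gives 0.609 h. Compound 2 `N#Cc1ccc(F)cc1Cn1c(N2CCC[C@@H](N)C2)nc2cc[nH]c2c1=O` has hydrogen on that carbon. Compound 2 reads > 1 h, which is a limit of the assay and not a number. Compound 3 `N#Cc1ccc(F)cc1Cn1c(N2CCC[C@@H](N)C2)nc2c(-c3ccc(S(N)(=O)=O)cc3)c[nH]c2c1=O` has 4-sulfamoylphenyl there instead. Compound 3 reads > 3.33 h, and this too is only a limit.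

Three measured steps frame the next change. The hydrogen swap gives an at least 1.6-fold higher number from compound 1 to compound 2 (0.21 log units; that floor lies within the scatter), the sulfamoylphenyl swap gives an at least 5.4-fold higher number from compound 1 to compound 3 (0.73 log units; beyond the scatter), and the third comparison gives a step that the two limits leave unreadable from compound 2 to compound 3.

Compound 4 `CS(=O)(=O)c1ccc(-c2c[nH]c3c(=O)n(Cc4cc(F)ccc4C#N)c(N4CCC[C@@H](N)C4)nc23)c(F)c1` keeps the shared core and differs at one place, with 2-fluoro-4-(methylsulfonyl)phenyl in place of 4-sulfamoylphenyl on an aromatic carbon. Among the measured compounds shown here, no measured step exchanges one substituted phenyl for another, so the evidence is indirect. The nearest guide is an at least 5.4-fold higher number from compound 1 to compound 3 (0.73 log units; beyond the scatter), a step that ended in a phenyl group bearing a sulfur substituent, which compound 4 also has. In this assay, therefore, no step beyond the scatter is expected in either direction. The expected change is a number no higher from compound 3 to compound 4 (the limit leaves the size open). For compound 4 the estimated half-life is 3.3 h, with an expected range from 1.2 h to 7 h.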

Compound 4, half-life: 1.59 h
Compound 4: the middle estimate sits 2.1-fold (0.32 log units) above what was measured, and the stated range covers the measured number.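

In this assay, exchanging 4-sulfamoylphenyl for 2-fluoro-4-(methylsulfonyl)phenyl on this aromatic carbon gives an at least 2.0-fold lower number from compound 3 to compound 4 (0.32 log units; beyond the scatter), so two phenyl groups that both carry a sulfur substituent need not read alike here. Compound 3 reads > 3.33 h, which is a limit and not a number, so that step gives only a floor and its true size stays open: the limit of > 3.33 h in this assay, at which 1 of the 4 values shown sits.

Even so, the new group keeps a gain over thiophen-2-yl, with a 2.6-fold higher number from compound 1 to compound 4 (0.42 log units; beyond the scatter), and the sulfur-bearing phenyl groups of compound 3 and compound 4 both read higher than compound 1.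

The step from compound 2 to compound 4 cannot be read, so these compounds do not settle whether compound 4 truly differs from the compound with hydrogen on this carbon. The fluorine and the methylsulfonyl group also enter together, so neither can be credited alone; 4-(methylsulfonyl)phenyl without the fluorine would separate the two, and a phenyl group bearing an amine or a carboxylic acid would show whether sulfur is needed at all.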